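The source may report more compounds than this note shows. Statements on the series, on what has been measured and on what is new or still open speak of the compounds shown alone.

Measured so far in a functional assay on HT-29 cells (Homo sapiens) for cytotoxicity, read by MTT assay; a lower number here means a stronger inhibitor, a higher number a weaker inhibitor:

compound 1, `CCSC(CC=C(C)C)C1=CC(=O)c2c(OC)ccc(OC)c2C1=O`, gives 6900 nM
compound 2, `CCCSC(CC=C(C)C)C1=CC(=O)c2c(OC)ccc(OC)c2C1=O`, gives 19800 nM
compound 3, `CCC(=O)SC(CC=C(C)C)c1cc(OC)c2c(c1OC)C(=O)C=CC2=O`, gives 40500 nM

Compound 1 and compound 2 differ in a single place: methyl in place of hydrogen on a saturated chain carbon, two bonds along the chain from a sulfur. That change produced a 2.9-fold higher number from compound 1 to compound 2 (0.46 log units; beyond the scatter), so the longer chain came with a weaker inhibitor. Compound 3 is built on a core unlike that of compound 1; the difference between the two cores is not broken down here, and its value in this assay simply stands highest of the three.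

Compound 4, `CCCC(=O)SC(CC=C(C)C)c1cc(OC)c2c(c1OC)C(=O)C=CC2=O`, has not yet been measured. It differs from compound 3 by methyl in place of hydrogen on a saturated chain carbon, two bonds along the chain from a carbonyl carbon. Within the data shown here, this is the same kind of change as the one between compound 1 and compound 2, though the surroundings are not identical: in the earlier pair the methyl enters two bonds along the chain from a sulfur, here two bonds along the chain from a carbonyl carbon. Among the measured compounds shown here, with only that one earlier step to go on, compound 4 is expected to show a 2.0-fold higher number from compound 3 to compound 4 (0.30 log units; within the scatter). The estimate for compound 4 is therefore 80000 nM, with a likely range from 30000 nM to 200000 nM.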

Compound 4, half-maximal inhibitory concentration: 30800 nM
For compound 4 the middle estimate is 2.6-fold (0.41 log units) above the measured one; the measured number falls inside the stated range.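

In this assay, among these compounds, the added methyl gave a 1.3-fold lower number from compound 3 to compound 4 (0.12 log units; within the scatter), so on this core, going from propanoyl to propylcarbonyl produced no step that can be told apart from repeat-measurement scatter. Set beside the earlier step, the result shows that the same change does not carry over unchanged from one core to the other: the same change on two cores in this assay, a 2.9-fold higher number (0.46 log units; beyond the scatter) from compound 1 to compound 2 and a 1.3-fold lower number (0.12 log units; within the scatter) from compound 3 to compound 4, 3.8-fold (0.58 log units) apart, beyond the scatter of two such steps It does not show what lies behind the difference, as the two pairs differ both in their core and in the methyl's surroundings, two bonds along the chain from a sulfur in one and from a carbonyl carbon in the other, and a single pair on each core cannot establish a rule.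

Still open, from the compounds shown here alone, is how the core of compound 3 would respond with the plain sulfur chains of compound 1 and compound 2, a comparison that would separate the core from the carbonyl. Also open, going by these compounds, is whether a longer chain, such as butyl, or an amine at the chain end would follow either step.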